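The source may hold more compounds than are shown below. What is called first, only, known or untested is meant among the compounds shown, and "the series" means these compounds.

Compound 3 `O=c1nc(N2CCN(NCc3cc(F)cc(F)c3)CC2)sc2c([N+](=O)[O-])cc(C(F)(F)F)cc12` stands at the edge of what an ADME assay on Vero cells (Chlorocebus sabaeus) for cytotoxicity, read by MTT assay, with a stated time of 72 h (a lower number here means that less compound is tolerated, a higher number that more compound is tolerated), can report: in this assay compound 3 gives > 64 ug/mL, a limit rather than a number. Its two neighbours do the same. Compound 1 `CC(C)CN(CC(C)C)N1CCN(c2nc(=O)c3cc(C(F)(F)F)cc([N+](=O)[O-])c3s2)CC1` gives > 64 ug/mL, also a limit. Compound 2 `O=c1nc(N2CCN(NCc3ccc(F)cc3)CC2)sc2c([N+](=O)[O-])cc(C(F)(F)F)cc12` gives > 64 ug/mL, again a limit. All three values thus sit together at the limit of > 64 ug/mL in this assay, at which 3 of the 3 values shown sit. Compound 4 `Cc1ccc(CNN2CCN(c3nc(=O)c4cc(C(F)(F)F)cc([N+](=O)[O-])c4s3)CC2)cc1` differs from compound 3 by 4-methylphenyl in place of 3,5-difluorophenyl on a saturated chain carbon bound to an amine nitrogen, that is, the 3,5-difluorobenzyl becomes a 4-methylbenzyl on the amine nitrogen. The nearest measured steps are a step that the two limits leave unreadable from compound 2 to compound 3, a step that the two limits leave unreadable from compound 1 to compound 2 and a step that the two limits leave unreadable from compound 1 to compound 3; because all three values rest on (the limit of > 64 ug/mL in this assay, at which 3 of the 3 values shown sit), none of them shows whether swapping the group on that amine nitrogen moves tolerance at all. The expectation for compound 4 is therefore that its result again rests at the limit, with a step that the limit leaves unreadable from compound 3 to compound 4 that is expected to be none beyond the scatter. Compound 4 is expected to give 80 ug/mL, within a range from 40 ug/mL to 160 ug/mL.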

Compound 4, half-maximal cytotoxic concentration: > 64 ug/mL
Compound 4: only a limit was reported (the forecaster's own chance of this, stated with the estimate: 80%); the middle value does not contradict the limit.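

In this assay compound 4 gives > 64 ug/mL, which is a limit and not a number. Its steps from compound 1, compound 2 and compound 3 therefore cannot be read: the limit of > 64 ug/mL in this assay, at which 4 of the 4 values shown sit. The compounds shown leave open whether any of these groups on the amine nitrogen changes how much compound the cells tolerate.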